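Swapping a Dimethylamino for a Methoxymethyl on a Fluorinated Core

A few compounds are considered here, and "the series" means these few. Any claim that something is new, unique, unknown or untested is made for them only; others in the source may bear on it.

Of the compounds shown here, three built on one shared core have been measured in a functional assay on MCF7 cells (Homo sapiens) for cytotoxicity, read by neutral red uptake, with a stated time of 3 days; a higher number here means a weaker inhibitor, a lower number a stronger inhibitor. Compound 1 `CCc1c(F)c(N)c2c(=O)cc(-c3ccc(N)c(F)c3)oc2c1F` carries an ethyl group on that core and gives 130 nM. Compound 2 `Nc1ccc(-c2cc(=O)c3c(N)c(F)c(CO)c(F)c3o2)cc1F` carries a hydroxymethyl group in the same position and gives 62 nM. Compound 3 `CN(C)c1c(F)c(N)c2c(=O)cc(-c3ccc(N)c(F)c3)oc2c1F` carries a dimethylamino group there and gives 39 nM. Compound 3 has the lowest number of the three, but its gap to compound 2, a 1.6-fold lower number from compound 2 to compound 3 (0.20 log units; within the scatter), is within the scatter, so those two cannot be ranked; only against compound 1 is the step clear, a 3.3-fold lower number from compound 1 to compound 3 (0.52 log units; beyond the scatter).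

Compound 4 `COCc1c(F)c(N)c2c(=O)cc(-c3ccc(N)c(F)c3)oc2c1F` differs from compound 3 in a single place: methoxymethyl in place of dimethylamino on an aromatic carbon. The measured steps that bear on this are the ones that varied the same position, a 2.1-fold lower number from compound 1 to compound 2 (0.32 log units; beyond the scatter) and a 1.6-fold lower number from compound 2 to compound 3 (0.20 log units; within the scatter), and both were modest or within the scatter. Compound 2 is the nearest relative of compound 4, as hydroxymethyl and methoxymethyl are both short chains carrying an oxygen. The step expected, a 1.8-fold higher number from compound 3 to compound 4 (0.25 log units; within the scatter), is therefore small, because compound 2 gives 62 nM and compound 3 gives 39 nM. Compound 4 is estimated at 70 nM, with a range from 30 nM to 160 nM.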

Compound 4, half-maximal inhibitory concentration: 46 nM
Beside the measured number, compound 4's estimate is 1.5-fold (0.18 log units) above it; the measured number falls inside the stated range.
By their numbers in this assay, from the lowest: compounds 3, 4 and 2 (each within the scatter of the next); then compound 1.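

In this assay the exchange of dimethylamino for methoxymethyl comes to a 1.2-fold higher number from compound 3 to compound 4 (0.07 log units; within the scatter) and the addition of a methyl on the hydroxymethyl oxygen comes to a 1.3-fold lower number from compound 2 to compound 4 (0.13 log units; within the scatter) so compound 2, compound 3 and compound 4 cannot be ranked against one another. This position therefore accepts a nitrogen-linked group, a free hydroxymethyl and its methyl-capped form with no readable difference among them, which the earlier pair of compound 2 and compound 3 could only begin to suggest. The one clear step the new compound adds is a 2.8-fold lower number from compound 1 to compound 4 (0.45 log units; beyond the scatter) and it places compound 4 with the other two against the ethyl group of compound 1, so among these four compounds, ethyl alone stands apart, and only by a modest margin.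

No measurement shown gives a reason why these groups cannot be told apart or why ethyl differs from them. As far as these compounds go, a longer chain, a carboxylic acid or a plain amino group at this position remains open, so it is unknown whether any group here could produce a larger step than these modest ones.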